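Swapping a Carboxyphenyl for a Carboxybenzyl on the Amide Nitrogen

A few compounds are considered here, and "the series" means these few. Any claim that something is new, unique, unknown or untested is made for them only; others in the source may bear on it.

Of the compounds shown here, three have been tested in an assay on isolated protein for binding affinity to L-selectin (Homo sapiens), read by ELISA, tested at 500 uM; on this read-out lower numbers stand for less inhibition and higher numbers for more inhibition at the one concentration tested (going by the name of the read-out). Compound 1 `CCCCCCCCCCOc1cccc(OCCCCCC(=O)N(Cc2ccc(C(=O)OC)cc2)c2ccc(C(=O)OC)cc2)c1` gives 75%, compound 2 `O=C(O)c1ccc(N(C(=O)CCCCCBr)c2ccc(C(=O)O)cc2)cc1` gives 6%, and compound 3 `CCCCCCCCCCOc1cc(OCCCCCCCCCC)cc(OCCCCCC(=O)N(c2cccc(C(=O)O)c2)c2cccc(C(=O)O)c2)c1` gives 14%. Compound 3 therefore stands second highest of the three numbers: its value and that of compound 2 lie within the usual scatter of each other, while compound 1 sits far above it, beyond the scatter. Compound 4 `CCCCCCCCCCOc1cc(OCCCCCCCCCC)cc(OCCCCCC(=O)N(Cc2ccc(C(=O)O)cc2)c2cccc(C(=O)O)c2)c1` is the next compound to be measured. Its structure differs from compound 3 in one place: 4-carboxybenzyl in place of 3-carboxyphenyl on an amide-type nitrogen. In this assay the expected step is a number 11 percentage points higher from compound 3 to compound 4 (beyond the scatter), a rise that may only just exceed the scatter. For compound 4 the expected inhibition is 25%, with a range from 5% to 55%.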

Compound 4, a percentage reported as inhibition, at one concentration (the size of the read-out at that concentration, not a potency): 92%
The estimate for compound 4 lay 67 percentage points below the measured number, and the stated range ends below it.
By their numbers in this assay, from the lowest: compounds 2 and 3 (each within the scatter of the next); then compound 1; then compound 4.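

The amide nitrogen proves to be a highly sensitive position: in this assay, 4-carboxybenzyl in place of 3-carboxyphenyl gives a number 78 percentage points higher from compound 3 to compound 4 (beyond the scatter). On paper the swap looks modest, as both groups hold one six-membered aromatic ring, one hydrogen-bond donor, one hydrogen-bond acceptor and no net charge. No measurement available here accounts for the large rise.

The swap changes both the link to the nitrogen and the carboxyl placement, and the compounds shown cannot separate these two changes. A 3-carboxybenzyl group on this nitrogen would help tell them apart.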